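Shifting the Chlorine on the Benzoyl Ring of Compound 1

A few compounds are considered here, and "the series" means these few. Any claim that something is new, unique, unknown or untested is made for them only; others in the source may bear on it.

Measured so far in a functional assay on HCT-15 cells (Homo sapiens) for cytotoxicity, read by sulforhodamine B assay, with a stated time of 72 h; a lower number here means a stronger inhibitor of growth, a higher number a weaker inhibitor of growth:
Compound 1, `O=C(Nc1ccccc1O)C1CCc2ccccc2N1C(=O)c1ccccc1Cl`: compound 1 gives 44900 nM.
Compound 2, `O=C(Nc1ccc(O)cc1)C1CCc2ccccc2N1`: compound 2 reaches only the assay limit, > 100000 nM.
Compound 3, `O=C(Nc1ccccc1C(F)(F)F)C1CCc2ccccc2N1C(=O)c1ccccc1Cl`: compound 3 gives 4220 nM.

Compound 1 stands highest of the two numbers in this assay; the third value is a limit, (the limit of > 100000 nM in this assay, at which 1 of the 3 values shown sits). Among the compounds with values here, the only step between measured compounds is an 11-fold lower number from compound 1 to compound 3 (1.03 log units; beyond the scatter), through trifluoromethyl in place of hydroxy on an aromatic carbon, and it leaves the benzoyl part untouched.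

Compound 4, `O=C(Nc1ccccc1O)C1CCc2ccccc2N1C(=O)c1cccc(Cl)c1`, differs from compound 1 by 3-chlorophenyl in place of 2-chlorophenyl on a carbonyl carbon. Within the data shown here, no measured step touches the chlorophenyl on that carbonyl carbon, so nothing here points to a change beyond the scatter in this assay. Compound 4 is therefore estimated at 45000 nM, between 15000 nM and 130000 nM, which means an expected step of a 1.0-fold higher number from compound 1 to compound 4 (0.00 log units; within the scatter).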

Compound 4, concentration for 50% growth inhibition: 23100 nM
For compound 4 the middle estimate is 1.9-fold (0.29 log units) above the measured one, and the stated range covers the measured number.
By their numbers in this assay, from the lowest: compound 3; then compounds 4 and 1 (each within the scatter of the next). At a limit, above all of these: compound 2.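

Within the data shown here, this is the first measured change at the chlorophenyl on the carbonyl carbon, and in this assay it comes to a 1.9-fold lower number from compound 1 to compound 4 (0.29 log units; within the scatter), so this assay does not separate 3-chlorophenyl from 2-chlorophenyl at this place. Among these compounds, the change of hydroxy to trifluoromethyl, an 11-fold lower number from compound 1 to compound 3 (1.03 log units; beyond the scatter), remains the only step beyond the scatter. Nothing measured here accounts for either result.

Still open, from the compounds shown here alone, is how this place responds to a group other than chlorine, such as methoxy or an amine. Also open, going by these compounds, is whether 3-chlorophenyl gives a similar result when paired with trifluoromethyl instead of hydroxy.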